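Swapping Nitro for Chloro on the Benzothiazole Arm

The source may hold more compounds than are shown below. What is called first, only, known or untested is meant among the compounds shown, and "the series" means these compounds.

Compound 2 `O=c1cc(-c2ccccc2)oc2cc(OCCCCNc3nc4ccc([N+](=O)[O-])cc4s3)cc(O)c12` was tested in an ADME assay on MDCK cells (Canis lupus familiaris) for cytotoxicity, read by sulforhodamine B assay, with a stated time of 48 h; a lower number here means a stronger inhibitor, a higher number a weaker inhibitor. Going by the values given here, compound 2 gives 310 ug/mL, the lowest of the two numbers measured so far. Its nearest neighbour, compound 1 `O=c1cc(-c2ccccc2)oc2cc(OCCCCNc3nc4ccccc4s3)cc(O)c12`, gives 348 ug/mL in this assay. Among the compounds with values here, the only measured step between compounds that differ in one place runs a 1.1-fold lower number from compound 1 to compound 2 (0.05 log units; within the scatter), and the nitro group that sets these two apart changed nothing beyond the scatter.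

Compound 3 `O=c1cc(-c2ccccc2)oc2cc(OCCCCNc3nc4ccc(Cl)cc4s3)cc(O)c12` has not yet been measured. Compared with compound 2 it carries chloro in place of nitro on an aromatic carbon.

Within the data shown here, only the step from compound 1 to compound 2 touches this position, and it was small. Among the measured compounds shown here, there is no measured example of a chloro group at this position, so the expectation rests on that one step alone. Compound 3 is therefore expected to give a number close to that of compound 2, with the step of a 1.0-fold higher number from compound 2 to compound 3 (0.01 log units; within the scatter) staying within the scatter. Compound 3 is estimated at 320 ug/mL, in a range from 200 ug/mL to 500 ug/mL.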

Compound 3, half-maximal inhibitory concentration: 338 ug/mL
Beside the measured number, compound 3's estimate is 1.1-fold (0.02 log units) below it; the range from low to high includes it.
By their numbers in this assay, from the lowest: compounds 2, 3 and 1 (each within the scatter of the next).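

In this assay, exchanging the 6-nitro-1,3-benzothiazol-2-yl arm for the 6-chloro-1,3-benzothiazol-2-yl arm gives a 1.1-fold higher number from compound 2 to compound 3 (0.04 log units; within the scatter) even though a nitro group with two hydrogen-bond acceptors gives way to a single chlorine atom with none. Comparing chloro with the original hydrogen gives a 1.0-fold lower number from compound 1 to compound 3 (0.01 log units; within the scatter) and completes the set: hydrogen, nitro and chloro at this position all lie within the scatter of one another, so the earlier flat result is no longer confined to nitro alone. No supporting measurement explains why these three compounds read alike.

As far as these compounds go, whether this flat pattern extends beyond hydrogen, nitro and chloro remains open, since an amine or a carboxylic acid at the same position could still separate from these three compounds. From the compounds shown here alone, it is also open whether a longer chain linking the benzothiazole arm to the shared core would matter more than the group exchanged here.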